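This account rests on a few compounds, and the source may have more. Where it says the series, first, only, none or still open, it means among the compounds named here.

In a functional assay (QGY7701 cells, Homo sapiens) for inhibition, read by MTT assay, with a stated time of 48 h (on this read-out higher numbers stand for weaker inhibition and lower numbers for stronger inhibition), compound 1, with the structure `O=C(/C=C/c1coc2cc(O)ccc2c1=O)NCc1ccc(F)cc1`, gives > 100000 nM; this is a limit of the assay rather than a number. Compound 2, with the structure `COc1ccc2c(=O)c(/C=C/C(=O)Nc3cccc(Cl)c3)coc2c1`, gives > 100000 nM in this assay, again a limit and not a number. Both values sit at the limit of > 100000 nM in this assay, at which 2 of the 2 values shown sit, so compound 2 stands at the edge of what this assay can report, and the two results show no difference between compound 1 and compound 2.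

Compound 3 has the structure `COc1ccc2c(=O)c(/C=C/C(=O)Nc3ccc(C)cc3)coc2c1`. The change from compound 2 is 4-methylphenyl in place of 3-chlorophenyl on an amide-type nitrogen. Within the data shown here, no measured step of this kind is known here. The step expected from this change is a step that the limit leaves unreadable from compound 2 to compound 3, that is, no change beyond the scatter is expected in this assay. Compound 3 is therefore expected to give about 150000 nM in this assay, within a range from 50000 nM to 500000 nM, and most likely the result is again only a limit.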

Compound 3, half-maximal inhibitory concentration: 39300 nM
Compound 3: middle estimate off by 3.8-fold (0.58 log units), on the high side, and the stated range ends above it.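

In this assay, the group on the amide-type nitrogen proves able to move the read-out: 4-methylphenyl in place of 3-chlorophenyl gives an at least 2.5-fold lower number from compound 2 to compound 3 (0.40 log units; beyond the scatter). Among these compounds, because compound 2 gives only a limit, this step is a minimum and its full size cannot be read: the limit of > 100000 nM in this assay, at which 2 of the 3 values shown sit. Compound 3 is the only one of the three compounds with a number rather than a limit, so this position is the one place where a change can be followed here.

From the compounds shown here alone, the step swaps chlorine for methyl and also changes the numbering on the ring, so it remains open which of the two matters. 4-Chlorophenyl and 3-methylphenyl on the same nitrogen would separate them, and how an amine or a carboxylic acid on this ring would read also remains open.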